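Adding a chlorine to the amide aryl of compound 3

A few compounds are considered here, and "the series" means these few. Any claim that something is new, unique, unknown or untested is made for them only; others in the source may bear on it.

Measured compounds:
compound 1 `O=C(Nc1cccc(-n2cc(-c3ccncc3)c(-c3ccc(Cl)c(O)c3)n2)c1)Nc1cccc(C(F)(F)F)c1` — > 32500 nM
compound 2 `COc1cc(-c2nn(-c3cccc(NC(=O)Nc4cc(C(F)(F)F)cc(C(F)(F)F)c4)c3)cc2-c2ccncc2)ccc1Cl` — 3710 nM
compound 3 `COc1cc(-c2nn(-c3cccc(NC(=O)c4cccc(C(F)(F)F)c4)c3)cc2-c2ccncc2)ccc1Cl` — > 50000 nM

These three compounds were tested in a functional assay on HT-29 cells (Homo sapiens) for inhibition, read by sulforhodamine B assay, with a stated time of 48 h; a lower number here means that less compound is tolerated, a higher number that more compound is tolerated. Compound 3 gives > 50000 nM, which is a limit of the assay and not a number. Compound 1 also reaches a limit, at > 32500 nM. Among the measured compounds shown here, compound 2, a urea with two trifluoromethyl groups, is the only one with a measured number, 3710 nM. Compound 3 therefore stands at the tolerated end of what is shown, as noted in the limit of > 50000 nM in this assay, at which 1 of the 3 values shown sits.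

Compound 4 `COc1cc(-c2nn(-c3cccc(NC(=O)c4ccc(Cl)c(C(F)(F)F)c4)c3)cc2-c2ccncc2)ccc1Cl` differs from compound 3 in one place: chloro in place of hydrogen on an aromatic carbon. For the measured compounds named here, no measured pair shows this exact change, so its size cannot be read off. The nearest hint is that compound 2, which carries more halogenated substitution on its amide-side aryl, gives a number rather than a limit, so some lowering of this assay value is possible. Since the starting point for compound 3 is a limit, the expected step from compound 3 to compound 4 is an at least 1.4-fold lower number from compound 3 to compound 4 (0.15 log units; that floor lies within the scatter), and compound 4 is estimated at 35000 nM, with a range from 8000 nM to 100000 nM.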

Compound 4, concentration lethal to 50% of the cells: > 32500 nM
Compound 4 ended at the assay's limit (the forecaster's own chance of this, stated with the estimate: 50%); the middle value is on the limit's open side.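

Among the compounds shown here, compound 3 and compound 4 both end at limits of the assay and not at numbers, so no step between them can be read in this assay. As far as these compounds go, whether going from 3-(trifluoromethyl)phenyl to 4-chloro-3-(trifluoromethyl)phenyl changes the value at all stays open, as neither compound has a measured number.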